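Cytotoxicity in Raji cells: three acids and a fourth

The source may report more compounds than this note shows. Statements on the series, on what has been measured and on what is new or still open speak of the compounds shown alone.

Compound 1 `CC(C)N(Cc1cccc(OCCCCCC(=O)O)c1)C(=O)c1ccc(-c2cccc3ccccc23)cc1`: a limit, > 26000 nM in an ADME assay on Raji cells (Homo sapiens) for cytotoxicity, read by CellTiter-Glo and resazurin assay, with a stated time of 72 h; on this read-out higher numbers stand for an effect only at larger amounts of compound and lower numbers for an effect already at smaller amounts.
Compound 2 `CC(C)N(Cc1cccc(OCCCCCC(=O)O)c1)C(=O)c1ccc(-c2cccc(Oc3ccccc3)c2)cc1`: a limit, > 18700 nM in this assay.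
Compound 3 `CC(C)N(Cc1cccc(OCCCCCC(=O)O)c1)C(=O)c1ccc(-c2ccsc2)cc1`: a limit, > 26000 nM in this assay.

All three values are limits, so compound 3 stands at the same limit as compound 1 and cannot be ordered against compound 2. The step from compound 1 to compound 3 is a step that the two limits leave unreadable from compound 1 to compound 3, unreadable because both ends are limits (the limit of > 26000 nM in this assay, at which 2 of the 3 values shown sit). Compound 4 `Cc1nnc(-c2cccc(-c3ccc(C(=O)N(Cc4cccc(OCCCCCC(=O)O)c4)C(C)C)cc3)c2)o1` differs from compound 3 by 3-(5-methyl-1,3,4-oxadiazol-2-yl)phenyl in place of thiophen-3-yl on an aromatic carbon. Among the measured compounds shown here, no measured step can be read, and the only evidence is that every value shown sits at a limit (the limit of > 18700 nM in this assay, at which 1 of the 3 values shown sits, (the limit of > 26000 nM in this assay, at which 2 of the 3 values shown sit)). Compound 4 is therefore expected to sit at a limit as well, with the step from compound 3 to compound 4 estimated as a step that the limit leaves unreadable from compound 3 to compound 4. The estimate for compound 4 is 30000 nM, in the range 8000 nM to 100000 nM.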

Compound 4, half-maximal effective concentration: > 26000 nM
Compound 4: no number, only a limit; the forecaster's own chance of this, stated with the estimate: 80%; the middle value is on the limit's open side.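

Compound 4 also gives only a limit, so none of its steps from compound 1, compound 2 or compound 3 can be read. The compounds shown leave open how these four would rank in this assay.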